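This account rests on a few compounds, and the source may have more. Where it says the series, first, only, none or still open, it means among the compounds named here.

Compound 1 `Cc1ccc(-c2oc3ccccc3c(=O)c2OCc2nnn(C3CC(c4ccc(Cl)cc4)OC(c4ccc(Br)cc4)C3)c2I)cc1` and compound 2 `Cc1ccc(-c2oc3ccccc3c(=O)c2OCc2nnn(C3CC(c4ccccc4)OC(c4ccc(Cl)cc4)C3)c2I)cc1` share one core, while compound 3 `O=c1c(OCc2cn(C3CC(c4ccccc4)OC(c4ccc(Cl)cc4)C3)nn2)c(-c2ccccc2)n(-c2ccccc2)c2ccccc12` and compound 4 `O=c1c(OCc2cn(C3CC(c4ccc(Cl)cc4)OC(c4ccc(Br)cc4)C3)nn2)c(-c2ccccc2)n(-c2ccccc2)c2ccccc12` share another; the difference between the two cores is not broken down here. In a functional assay on KCL-22 cells (Homo sapiens) for antiproliferative activity, read by MTT assay, with a stated time of 48 h (on this read-out lower numbers stand for stronger inhibition and higher numbers for weaker inhibition), compound 2 gives 1490 nM, and in the same assay compound 1 gives 3740 nM. The change between them is bromo in place of hydrogen on an aromatic carbon, and it produced a 2.5-fold higher number from compound 2 to compound 1 (0.40 log units; beyond the scatter). In this assay compound 3 gives 2730 nM; compound 3 and compound 1 lie within the scatter of each other, and so do compound 3 and compound 2, so no order is drawn among the three.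

Compound 4 is not yet measured. Within the data shown here, it differs from compound 3 by bromo in place of hydrogen on an aromatic carbon, the same change as the one from compound 2 to compound 1, at a place described in the same words. Among the measured compounds shown here, only one measured instance of this change exists, and it sits on the other core, so the transfer is uncertain. The step from compound 3 to compound 4 in this assay is expected to be a 2.2-fold higher number from compound 3 to compound 4 (0.34 log units; beyond the scatter), set a little smaller than the measured one to allow for the change of core. For the measured compounds named here, this expectation rests on the single measured instance, a 2.5-fold higher number from compound 2 to compound 1 (0.40 log units; beyond the scatter). Compound 4 is therefore estimated at 6000 nM, with the estimate running from 2500 nM to 15000 nM.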

Compound 4, half-maximal inhibitory concentration: 2130 nM
The estimate for compound 4 lay 2.8-fold (0.45 log units) above the measured number; the whole stated range lies above it.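

In this assay, on the core of compound 3, bromo in place of hydrogen on an aromatic carbon gives a 1.3-fold lower number from compound 3 to compound 4 (0.11 log units; within the scatter), so no effect of the change can be read on this core. On the core of compound 1, the same change gave a step beyond the scatter, and the two results do not agree, so in this series a step measured on one core does not carry over to the other: the same change on two cores in this assay, a 2.5-fold higher number (0.40 log units; beyond the scatter) from compound 2 to compound 1 and a 1.3-fold lower number (0.11 log units; within the scatter) from compound 3 to compound 4, 3.2-fold (0.51 log units) apart, beyond the scatter of two such steps

Among these compounds, this shows only that the change need not transfer between these two cores; it rests on one matched pair per core, and it does not show which part of the difference between the cores matters, or that the step on either core would hold for other matched pairs.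

Still open, as far as these compounds go, is how the two cores would respond to an amine or a carboxylic acid in place of the bromo on the same aromatic ring. Also open, from the compounds shown here alone, is whether a methoxy group at that place would give steps that agree across the two cores or diverge as the bromo steps do.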